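Hydroxy for methoxy: cytotoxicity notes on two analogues

The source may report more compounds than this note shows. Statements on the series, on what has been measured and on what is new or still open speak of the compounds shown alone.

Measured so far:
compound 1 `Cc1cc(O)cc(-c2nn(CC#N)cc2-c2ccnc(-c3ccc(Oc4ccccc4)cc3)c2)c1` — 96%
compound 2 `COc1cc(C)cc(-c2nn(CC#N)cc2-c2ccnc(-c3ccc(N(C)C)cc3)c2)c1` — 93%

In a functional assay on M14 cells (Homo sapiens) for cytotoxicity, read by sulforhodamine B assay, with a stated time of 48 h, tested at 0.01 uM (a lower number here means a stronger effect, a higher number a weaker effect of the compound at the concentration tested), compound 1 gives 96%. In this assay compound 2 gives 93%. Compound 2 holds the lowest of the two numbers, but its nearest neighbour, compound 1, is only a few points higher and within the scatter, so no order can be read between them. Both numbers sit near the top of the percentage scale, which at this concentration means a weak effect for either compound.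

Compound 3 `Cc1cc(O)cc(-c2nn(CC#N)cc2-c2ccnc(-c3ccc(N(C)C)cc3)c2)c1` has not yet been measured. Against compound 2 the change is hydrogen in place of methyl on an oxygen on an aromatic ring. Among the measured compounds shown here, no pair of measured compounds isolates this change. Compound 1 already carries the 3-hydroxy-5-methylphenyl group, together with a different group on the other end, and in this assay compound 1 gives 96%, no different beyond the scatter from compound 2. Compound 3 is therefore expected to show no step beyond the scatter, a number 1 percentage points higher from compound 2 to compound 3 (within the scatter). Compound 3 is estimated at 94%, within 84% to 100%.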

Compound 3, a percentage reported as activity, at one concentration (the size of the read-out at that concentration, not a potency): 92%
Compound 3: middle estimate off by 2 percentage points, on the high side, and the stated range covers the measured number.
By their numbers in this assay, from the lowest: compounds 3, 2 and 1 (each within the scatter of the next).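

The methoxy to hydroxy change is now isolated in one pair of compounds: in this assay, hydrogen in place of methyl on an oxygen on an aromatic ring gives a number 1 percentage points lower from compound 2 to compound 3 (within the scatter), so at this concentration the read-out does not separate the 3-methoxy-5-methylphenyl and 3-hydroxy-5-methylphenyl groups. With the 3-hydroxy-5-methylphenyl group held fixed, dimethylamino in place of phenoxy on an aromatic carbon gives a number 4 percentage points lower from compound 1 to compound 3 (within the scatter), so the change at the other end does not separate its pair either. Nothing available here bears on the reason for either result.

All three numbers sit near the top of the scale, so these pairs leave open whether either change would matter at a concentration where the compounds have a stronger effect. Also open, on these data alone, is whether a longer chain on the same oxygen, such as ethoxy or propoxy, or a carboxylic acid or primary amine in place of the hydroxy group, would move the read-out beyond the scatter.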